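The source may hold more compounds than are shown below. What is called first, only, known or untested is meant among the compounds shown, and "the series" means these compounds.

Four compounds share one core. Compound 1 `COc1ccc(/C=C\C(=O)O)c(OCc2cn(-c3ccc(NC(C)=O)cc3)nn2)c1CC=C(C)C` was put into a functional assay on A549 cells (Homo sapiens) for cytotoxicity, read by MTT assay, with a stated time of 24 h (a higher number here means a weaker inhibitor, a lower number a stronger inhibitor), where compound 1 shows "not determined" (no result reported). Compound 2 `COc1ccc(/C=C\C(=O)O)c(OCc2cn(-c3cccc(C#N)c3)nn2)c1CC=C(C)C` was also put into this assay, and there compound 2 shows "not determined" (no result reported). Compound 3 `COc1ccc(/C=C\C(=O)O)c(OCc2cn(-c3ccccc3I)nn2)c1CC=C(C)C` is the only one of the four with a number: in this assay compound 3 gives 2200 nM, so it stands alone and cannot be ranked against anything. Compound 4 `COc1ccc(/C=C\C(=O)O)c(OCc2cn(-c3ccc(C#N)cc3)nn2)c1CC=C(C)C` differs from compound 3 in one place: 4-cyanophenyl in place of 2-iodophenyl on an aromatic nitrogen. For the measured compounds named here, no step between two measured compounds is available, so no direction can be read from data. The change from compound 3 is expected to shift the result by little, if at all, beyond the usual scatter, and a 1.4-fold higher number from compound 3 to compound 4 (0.13 log units; within the scatter) is the estimated step. For compound 4 the expected value in this assay is 3000 nM, within a range from 1000 nM to 9000 nM.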

Compound 4, half-maximal inhibitory concentration: 42200 nM
Beside the measured number, compound 4's estimate is 14-fold (1.15 log units) below it; measured number outside the range, above it.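

In this assay, putting 4-cyanophenyl in place of 2-iodophenyl on the aromatic nitrogen gives a 19-fold higher number from compound 3 to compound 4 (1.28 log units; beyond the scatter), the first readable comparison, and it shows that the result is sensitive to the group at this position. This one change alters both the substituent and where it sits on the phenyl ring, so the step cannot be assigned to either alone. Nothing available explains the loss of activity.
Still open, going by these compounds, is how a plain phenyl, a 4-iodophenyl or a 2-cyanophenyl would behave here, and whether the substituent or its place on the ring carries the step.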